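The compounds below may be only part of what the source reports. "The series", "measured", "known", "first", "only" and "open" are said of these compounds alone.

Compound 1 `Cc1ccccc1S(=O)(=O)Nc1ccc2oc(-c3ccccc3)nc2c1` gives 57000 nM in an ADME assay on HEK293 cells (Homo sapiens) for cytotoxicity, read by resazurin assay, with a stated time of 48 h; on this read-out lower numbers stand for higher toxicity in this test and higher numbers for lower toxicity in this test.
Compound 2 `COc1ccc(Cl)cc1S(=O)(=O)Nc1ccc(-c2nc3ccccc3o2)cc1` gives 75000 nM in this assay.
Compound 3 `O=S(=O)(Nc1ccc2oc(-c3ccccc3)nc2c1)c1ccccc1Cl` gives 73000 nM in this assay.

All three compounds share a core built from a sulfonamide linking two aromatic pieces, and all three sit close together in this assay: compound 2 stands within the scatter of both compound 3 and compound 1, so no order among the three can be claimed.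

Compound 4 `O=S(=O)(Nc1ccc(-c2nc3ccccc3o2)cc1)c1cccc(F)c1` is not yet measured. It differs from compound 2 in one place: 3-fluorophenyl in place of 5-chloro-2-methoxyphenyl on a sulfonyl sulfur.

Within the data shown here, only one measured step touches the group on the sulfonyl sulfur. From compound 1 to compound 3, chloro in place of methyl on an aromatic carbon gave a 1.3-fold higher number from compound 1 to compound 3 (0.11 log units; within the scatter). That change and the present one alter the same part of the molecule, and the measured one stayed within the scatter. For compound 4 a step of about a 1.1-fold lower number from compound 2 to compound 4 (0.03 log units; within the scatter) is therefore expected, that is, none beyond the scatter. The estimate for compound 4 is 70000 nM, with a range from 35000 nM to 140000 nM.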

Compound 4, half-maximal cytotoxic concentration: > 100000 nM
Compound 4 was reported as a limit (the forecaster's own chance of this, stated with the estimate: 20%); middle value at least 1.4-fold (0.15 log units) away from the limit.
By their numbers in this assay, from the lowest: compounds 1, 3 and 2 (each within the scatter of the next). At a limit, above all of these: compound 4.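

Compound 4 is the first of the compounds shown to reach a limit of the assay rather than give a number: the limit of > 100000 nM in this assay, at which 1 of the 4 values shown sits. The exchange of the whole group on the sulfonyl sulfur gives an at least 1.3-fold higher number from compound 2 to compound 4 (0.12 log units; that floor lies within the scatter), so only a floor for this step is known, and whether the true step goes beyond the scatter cannot be read. Among these compounds, the one earlier step at this group changed only a single substituent, a 1.3-fold higher number from compound 1 to compound 3 (0.11 log units; within the scatter), whereas this one shows that replacing the entire 5-chloro-2-methoxyphenyl with 3-fluorophenyl did not move the read-out towards higher toxicity.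

From the compounds shown here alone, since chloro and methoxy leave together as fluoro enters, the contribution of each remains open. Going by these compounds, it is also open how a phenyl ring carrying an amine or a carboxylic acid on the sulfonyl sulfur would read in this assay.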